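This account rests on a few compounds, and the source may have more. Where it says the series, first, only, none or still open, it means among the compounds named here.

Measured so far:
compound 1 `Clc1ccc(OCC2=NCCO2)cc1`: 20%
compound 2 `Cc1cc(OCC2=NCCO2)ccc1Cl`: 30%

Going by the values given here, in a toxicity assay on the whole organism with Rattus norvegicus as the target, at a dose of 200 mg/kg by the oral route (on this read-out lower numbers stand for a weaker effect and higher numbers for a stronger effect at the one dose given), compound 1 gives 20%, and compound 2 gives 30%; the two stand within the scatter of each other, with a number 10 percentage points higher from compound 1 to compound 2 (within the scatter) the only step measured. Compound 3 `Fc1ccc(OCC2=NCCO2)cc1` differs from compound 1 by fluoro in place of chloro on an aromatic carbon. Among the compounds with values here, the single measured step, methyl in place of hydrogen on an aromatic carbon, concerns a different kind of change and says nothing about exchanging one halogen for another, so no step beyond the scatter is expected in this assay. Compound 3 is therefore estimated at 20%, between 5% and 40%, which means an expected step of no change at the digits printed from compound 1 to compound 3 (within the scatter).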

Compound 3, a percentage reported as activity, at one dose (the size of the read-out at that dose, not a potency): 25%
For compound 3 the middle estimate is 5 percentage points below the measured one; measured number inside the range.
By their numbers in this assay, from the lowest: compounds 1, 3 and 2 (each within the scatter of the next).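

Fluoro in place of chloro on the aromatic carbon para to a group of 7 heavy atoms gives a number 5 percentage points higher from compound 1 to compound 3 (within the scatter) in this assay on the whole animal. This is the first change shown at this position, and the exchange of one halogen for the other stays within the usual scatter. No separate measurement offers an explanation for this result. Going by these compounds, whether an amine, a methoxy group or a carboxylic acid at this position would also stay within the scatter remains open. So does the effect of this halogen exchange on the methyl-bearing compound 2 .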